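The source may report more compounds than this note shows. Statements on the series, on what has been measured and on what is new or still open speak of the compounds shown alone.

The measured compounds:

Compound 1 `COc1ccc(C(=O)Nc2ccc(Cl)cc2F)c(O)c1` gives 32300 nM in an ADME assay on RAW264.7 cells (Mus musculus) for cytotoxicity, read by MTT assay, with a stated time of 24 h; a higher number here means that more compound is tolerated, a lower number that less compound is tolerated.
Compound 2 `O=C(Nc1ccc(F)cc1F)c1ccccc1` gives > 40000 nM in this assay, and this is a limit of the assay, not a number.

Compound 2 therefore stands only at a limit on the numbers shown: of the two measured compounds, it is the one that sits at the limit of > 40000 nM in this assay, at which 1 of the 2 values shown sits. Within the data shown here, compound 1 is the only compound with a measured number, and its structure is unrelated to compound 3 apart from the shared amide.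

Compound 3 `O=C(Nc1ccc(I)cc1F)c1ccccc1` differs from compound 2 in one place: iodo in place of fluoro on an aromatic carbon. Among the measured compounds shown here, no pair of measured compounds shows how such an exchange moves this assay, so the direction and size of the step can only be expected, not read off. The step from compound 2 to compound 3 is expected to be an at least 1.3-fold lower number from compound 2 to compound 3 (0.12 log units; that floor lies within the scatter), a modest move toward less compound being tolerated, with the chance of another limit remaining substantial.

On that basis compound 3 is estimated to give 30000 nM in this assay, within a range of 10000 nM to 80000 nM.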

Compound 3, half-maximal cytotoxic concentration: > 40000 nM
Compound 3: no number, only a limit (the forecaster's own chance of this, stated with the estimate: 40%); at least 1.3-fold (0.12 log units) between middle value and limit.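

Compound 2 and compound 3 both end at a limit, not a number, in this assay, so no step can be read for iodo in place of fluoro between them: the limit of > 40000 nM in this assay, at which 2 of the 3 values shown sit.

The compounds shown leave open how far either compound lies past that limit, and whether this exchange moves the half-maximal cytotoxic concentration at all.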